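Swapping hydroxy for amino on a dithiole scaffold

A few compounds are considered here, and "the series" means these few. Any claim that something is new, unique, unknown or untested is made for them only; others in the source may bear on it.

Measured so far:
compound 1, `COc1ccc(-c2ssc(=O)c2-c2cc(OC)c(OC)c(OC)c2)cc1O`: 1910 nM
compound 2, `COc1ccc(-c2ssc(=O)c2-c2cc(OC)c(OC)c(OC)c2)cc1N`: 147 nM
compound 3, `CO/N=c1/ssc(-c2ccc(OC)c(O)c2)c1-c1cc(OC)c(OC)c(OC)c1`: 4600 nM

All three compounds were tested in a functional assay on HT-1080 cells (Homo sapiens) for antiproliferative activity, read by MTT assay, with a stated time of 72 h; on this read-out higher numbers stand for weaker inhibition and lower numbers for stronger inhibition. Among the compounds with values here, compound 1 and compound 2 share one core, and the single change between them, (amino in place of hydroxy on an aromatic carbon), produced a 13-fold lower number from compound 1 to compound 2 (1.11 log units; beyond the scatter). Compound 3 carries a different core; the difference between the two cores is not broken down here. In this assay compound 3 gives the highest of the three numbers, and its nearest neighbour is compound 1 with 1910 nM.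

Compound 4, `CO/N=c1/ssc(-c2ccc(OC)c(N)c2)c1-c1cc(OC)c(OC)c(OC)c1`, has not yet been measured. It relates to compound 3 exactly as compound 2 relates to compound 1: amino in place of hydroxy on an aromatic carbon. The surroundings of the changed position are described in the same words for both pairs, so this is the same change made on a second core.

Within the data shown here, with only one earlier example of this change, and that example on a different core, the expected step from compound 3 to compound 4 is estimated at a 10-fold lower number from compound 3 to compound 4 (1.01 log units; beyond the scatter), resting on the size of a 13-fold lower number from compound 1 to compound 2 (1.11 log units; beyond the scatter). It is not certain that a change seen on one core carries over unchanged to another, so the expected range is kept wide. Compound 4 is therefore expected to give about 450 nM in this assay, with an estimated range from 150 nM to 1500 nM.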

Compound 4, half-maximal inhibitory concentration: 4230 nM
Compound 4: the middle estimate sits 9.4-fold (0.97 log units) below what was measured; the measured number lies above the stated range.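

On the second core the swap does not repeat what it did on the first: in this assay, amino in place of hydroxy gave a 1.1-fold lower number from compound 3 to compound 4 (0.04 log units; within the scatter), so compound 3 and compound 4 cannot be told apart. Set side by side, the two results show that the size of this change depends on the core that carries it, and that a result from one core could not be transferred to the other in this series: the same change on two cores in this assay, a 13-fold lower number (1.11 log units; beyond the scatter) from compound 1 to compound 2 and a 1.1-fold lower number (0.04 log units; within the scatter) from compound 3 to compound 4, 12-fold (1.08 log units) apart, beyond the scatter of two such steps

This does not show what in the cores produces the difference, since the two cores are not broken down into single changes, and one pair per core says nothing about how the swap would behave on a third core.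

The compounds shown leave open how other groups would behave at the same place, such as a fluorine, a methylamino group or an acetamide in place of the hydroxy or amino on each core. They also leave open whether any such group would separate the two cores in the way amino and hydroxy do, or whether the core of compound 3 would leave those values as close together as it does here.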